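The source may report more compounds than this note shows. Statements on the series, on what has been measured and on what is new or still open speak of the compounds shown alone.

Of the compounds shown here, two have been tested in a functional assay on A2780 cells (Homo sapiens) for inhibition, read by sulforhodamine B assay, with a stated time of 72 h; on this read-out lower numbers stand for stronger inhibition and higher numbers for weaker inhibition. Compound 1 `CC(NC(=O)c1cc2cnccc2[nH]1)c1ccc(S(=O)(=O)N2CCCCC2)cc1` returns only a limit in this assay, > 10000 nM, so no number stands for it. Among the measured compounds shown here, compound 2 `O=C(NCc1ccc(S(=O)(=O)c2ccccc2)cc1)c1nc2cnccc2[nH]1` gives 5400 nM in this assay and is thus the only compound with a measured value. For compound 1 the result is the limit (the limit of > 10000 nM in this assay, at which 1 of the 2 values shown sits). Compound 3 `O=C(NCc1ccc(S(=O)(=O)c2ccccc2)cc1)c1ccc2nccn2c1` has not yet been measured. Compared with compound 2, it differs on the carbonyl carbon: a group of 9 heavy atoms (7 carbon, 2 nitrogen; one five-membered aromatic ring with 2 hetero atoms, one six-membered aromatic ring with 1 hetero atom) in place of a group of 9 heavy atoms (6 carbon, 3 nitrogen; one five-membered aromatic ring with 2 hetero atoms, one six-membered aromatic ring with 1 hetero atom), on a carbonyl carbon. For the measured compounds named here, no two measured compounds differ in a single place, so no measured step guides the expectation. Compound 2 already sits at 5400 nM, a weak value in this assay. The replacement is expected to leave compound 3 weak in this assay, with an expected step of a 1.5-fold higher number from compound 2 to compound 3 (0.17 log units; within the scatter) that may well not exceed the usual scatter. Compound 3 is therefore estimated at 8000 nM in this assay, with a plausible range from 2500 nM to 25000 nM, and a real chance that only a limit is reported.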

Compound 3, half-maximal inhibitory concentration: 13 nM
Compound 3: the middle estimate sits 620-fold (2.79 log units) above what was measured, outside the stated range (below it).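

In this assay, among the compounds shown here, the group on the carbonyl carbon turns out to decide much of the read-out, which the earlier compounds could not show, since no two of them differed in a single place: the exchange gives a 420-fold lower number from compound 2 to compound 3 (2.62 log units; beyond the scatter). The two groups match in heavy atom count, in their ring types and in hydrogen-bond acceptors, and differ only in 7 carbon, 2 nitrogen against 6 carbon, 3 nitrogen, and in 0 hydrogen-bond donors against 1 hydrogen-bond donor, so a small change in composition at this position is enough for a step of this size. Nothing measured here tells which of these differences carries the step.

This one pair cannot separate the nitrogen count from the loss of the donor, and it cannot show whether the step would recur elsewhere in the series. It also leaves open whether compound 3, at 13 nM, would keep that value if an amine or a carboxylic acid were attached to the group on the carbonyl carbon.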